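The source may hold more compounds than are shown below. What is called first, only, known or untested is meant among the compounds shown, and "the series" means these compounds.

In an assay (Equus caballus) for inhibition of Thromboxane-A synthase (Homo sapiens), using microsomes (on this read-out lower numbers stand for stronger inhibition and higher numbers for weaker inhibition), compound 1 `CC(C)(O)C(CCC/C=C(\c1ccccc1)c1cccnc1)C(=O)O` gives 42 nM, the second highest of the three numbers measured. Compound 2 `CC(C)(CCCC/C=C(/c1ccccc1)c1cccnc1)C(=O)O` gives 38 nM in this assay, which lies within the scatter of compound 1. Compound 3 `COc1ccc(/C(=C/CCCCC(=O)O)c2cccnc2)cc1` gives 80 nM in this assay, a gap from compound 1 that also stays within the scatter. Compound 4 `C=CCC(CCC/C=C(\c1ccccc1)c1cccnc1)C(=O)O` has not yet been measured in this assay. It differs from compound 1 in one place: allyl in place of 1-hydroxy-1-methylethyl on a saturated chain carbon bound to a carbonyl carbon and a saturated chain carbon. Among the measured compounds shown here, no step between measured compounds shows how such a change acts on this read-out, and the three measured compounds sit close together. A small step, a 1.2-fold higher number from compound 1 to compound 4 (0.08 log units; within the scatter), is therefore expected, none beyond the scatter. Compound 4 is expected to give 50 nM in this assay, with a likely range from 20 nM to 130 nM.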

Compound 4, half-maximal inhibitory concentration: 50 nM
Estimate against measurement, compound 4: no gap at the digits printed; low and high end bracket the measured number.
By their numbers in this assay, from the lowest: compounds 2, 1, 4 and 3 (each within the scatter of the next, the first and the last beyond it).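

In this assay, allyl in place of 1-hydroxy-1-methylethyl on a saturated chain carbon bound to a carbonyl carbon and a saturated chain carbon gives a 1.2-fold higher number from compound 1 to compound 4 (0.08 log units; within the scatter). At this position, then, the read-out stays within the scatter when the hydrogen-bond donor and hydrogen-bond acceptor of the leaving group are gone and a double bond outside aromatic rings enters. Nothing measured here explains this result. The compounds shown leave open whether an amine or a longer chain on this carbon would also stay within the scatter. They also leave open whether any group here moves the number beyond it.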